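Trimming the Warhead: From Crotonamide to Acrylamide

The source may hold more compounds than are shown below. What is called first, only, known or untested is meant among the compounds shown, and "the series" means these compounds.

In a functional assay on JeKo-1 cells (Homo sapiens) for inhibition, read by luminescence and CellTiter-Glo, with a stated time of 72 h (on this read-out lower numbers stand for stronger inhibition and higher numbers for weaker inhibition), compound 3 `C/C=C/C(=O)Nc1ccc(Cn2nc(-c3ccc(Oc4ccccc4)cc3)cc2C(=O)OCC)cc1` gives 52500 nM, the highest of the three numbers recorded, meaning the weakest inhibition of the set. Compound 1 `O=C(CCl)N1CCCC(n2nc(-c3ccc(Oc4ccccc4)cc3)cc2CO)C1` gives 7800 nM in this assay, a gap to compound 3 that lies beyond the usual scatter. Compound 2 `O=C(CCl)Nc1cccc(Cn2nc(-c3ccc(Oc4ccccc4)cc3)cc2CO)c1` gives 400 nM, the lowest number here, and stands furthest from compound 3. For the measured compounds named here, both compound 1 and compound 2 carry a chloroacetyl group where compound 3 carries an unsaturated acyl group, so no single-change step to compound 3 is available.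

Compound 4 `C=CC(=O)Nc1ccc(Cn2nc(-c3ccc(Oc4ccccc4)cc3)cc2C(=O)OCC)cc1` differs from compound 3 in one place: vinyl in place of prop-1-en-1-yl on a carbonyl carbon. The acyl chain thus shrinks by one carbon while the double bond outside the aromatic rings is kept. Going by the values given here, no pair of measured compounds shows this change, so its effect must be estimated rather than read. The expectation is a moderate step in this assay toward lower numbers, a 6.6-fold lower number from compound 3 to compound 4 (0.82 log units; beyond the scatter), beyond the scatter but not reaching the level of compound 2. Compound 4 is estimated at 8000 nM, with a plausible range from 2000 nM to 30000 nM.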

Compound 4, half-maximal inhibitory concentration: 10900 nM
The estimate for compound 4 lay 1.4-fold (0.13 log units) below the measured number, within the range that was stated.
By their numbers in this assay, from the lowest: compound 2; then compounds 1 and 4 (each within the scatter of the next); then compound 3.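

Vinyl in place of prop-1-en-1-yl on a carbonyl carbon gives a 4.8-fold lower number from compound 3 to compound 4 (0.68 log units; beyond the scatter) in this assay and is the first comparison in this set that isolates a single change. It shows that this position, where the carbonyl carbon's other neighbour is an amide-type nitrogen, responds to the loss of one carbon from the acyl chain even though the double bond is kept; compound 1 and compound 2 could not show this, as each differs from compound 3 in more than one place. Nothing in the data explains why the number moves.

On these data alone, whether a longer chain or a dimethylamino group at the end of the unsaturated chain would shift the number further remains open. So does the effect of a carboxylic acid in place of the ethyl ester on the core of compound 4.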